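A few compounds are considered here, and "the series" means these few. Any claim that something is new, unique, unknown or untested is made for them only; others in the source may bear on it.

Of the compounds shown here, two have so far been tested in a functional assay on the whole organism for antagonist activity, with Mus musculus as the target (on this read-out lower numbers stand for an effect already at smaller amounts and higher numbers for an effect only at larger amounts of compound), and neither gave a number. Compound 2 (`COC(=O)N(C)CC#CCn1ccnc1`) reads > 100 mg/kg in this assay and this value is a limit of the assay, not a measured dose. Compound 1 (`COC(=O)NCC#CCn1cncc1C`) reads > 100 mg/kg and this too is a limit. Going by these compounds, the whole record so far is the limit of > 100 mg/kg in this assay, at which 2 of the 2 values shown sit, and nothing more, so compound 2 cannot be ranked against compound 1, and its true position remains open.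

Compound 3 (`COC(=O)N(C)CC#CCn1cncc1C`) is made from compound 2 by a single change, with methyl in place of hydrogen on an aromatic carbon. The carbon concerned lies next to the ring nitrogen and next to the ring atom that bears a large group. Within the data shown here, no measured step shows what such a change does in this assay and any expectation is therefore loose. Only a modest move toward effect at smaller amounts is expected, and the estimated step (an at least 1.2-fold lower number from compound 2 to compound 3 (0.09 log units; that floor lies within the scatter)) may not clear the usual scatter. For compound 3 the estimate is 80 mg/kg with an expected range from 25 mg/kg to 300 mg/kg and a fair chance that the assay again returns only a limit.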

Compound 3, dose for half-maximal effect: > 100 mg/kg
Compound 3 ended at the assay's limit; the forecaster's own chance of this, stated with the estimate: 55%; at least 1.2-fold (0.09 log units) between middle value and limit.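

In this assay compound 3, like compound 1 and compound 2, reads only as a limit, so the steps to compound 3 from compound 2 and from compound 1 cannot be read: the limit of > 100 mg/kg in this assay, at which 3 of the 3 values shown sit.

The compounds shown leave open how far each lies from that limit, and whether either methyl in place of hydrogen changes the dose at all.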